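Side-chain oxidation: notes on compound 2 to compound 3

This account rests on a few compounds, and the source may have more. Where it says the series, first, only, none or still open, it means among the compounds named here.

Compound 1 `C[C@H]1CC[C@@]23C1=C[C@@]1(C)CC[C@](C)(C[C@H](O)[C@H](O)[C@@](C)(O)CO)[C@H]1[C@@H]2C[C@@H](O)[C@@H]3C` and compound 2 `C[C@H]1CC[C@@]23C1=C[C@@]1(C)CC[C@](C)(C[C@H](O)[C@H](O)[C@@](C)(O)CO)[C@H]1[C@@H]2CC[C@@H]3C` share one core. In a functional assay on cells (Panel NCI-60 (60 carcinoma cell lines), Homo sapiens) for inhibition (a lower number here means a stronger inhibitor, a higher number a weaker inhibitor), compound 1 gives 18000 nM and compound 2 gives 18000 nM; the step of no change at the digits printed from compound 1 to compound 2 (within the scatter) leaves compound 2 level with compound 1. Compound 3 `C[C@H]1CC[C@@]23C1=C[C@@]1(C)CC[C@](C)(C[C@H](O)C(=O)[C@@](C)(O)CO)[C@H]1[C@@H]2CC[C@@H]3C` differs from compound 2 by a group of 7 heavy atoms (4 carbon, 3 oxygen; no ring) in place of a group of 7 heavy atoms (4 carbon, 3 oxygen; no ring), on a saturated chain carbon bound to an oxygen on a saturated carbon and a saturated chain carbon. Among the measured compounds shown here, no measured step touches this part of the chain; the one step available, no change at the digits printed from compound 1 to compound 2 (within the scatter), is the sole guide. Compound 3 is therefore expected to show no change at the digits printed from compound 2 to compound 3 (within the scatter). The estimate for compound 3 is 18000 nM, with a range of 6000 nM to 54000 nM.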

Compound 3, half-maximal inhibitory concentration: 18000 nM
Compound 3: middle estimate and measured number agree at the digits printed, and the stated range covers the measured number.
By their numbers in this assay, from the lowest: compounds 1, 2 and 3 (each within the scatter of the next).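

In this assay the side chain now has a step of its own, no change at the digits printed from compound 2 to compound 3 (within the scatter), whereas the earlier step lay on a saturated ring carbon. Across compounds 1, 2 and 3, neither a hydroxy removed from the ring nor a carbonyl introduced on the chain separates the values. No supporting data bear on why this chain change leaves the value level. Going by these compounds, whether an amine or a carboxylic acid on this part of the chain would shift the value stays open. So does whether a longer chain would.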